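Dropping the fluorine from compound 2: benzyl in place of 2-fluorobenzyl

A few compounds are considered here, and "the series" means these few. Any claim that something is new, unique, unknown or untested is made for them only; others in the source may bear on it.

Compound 1 `CCn1c(CN2CCN(C(=O)C3CC3)CC2)nc2ccccc21`: 20.8%
Compound 2 `O=C(C1CC1)N1CCN(Cc2nc3ccccc3n2Cc2ccccc2F)CC1`: 40.7%
Compound 3 `CC(C)CCn1c(CN2CCN(C(=O)c3ccco3)CC2)nc2ccccc21`: 42.1%

The three compounds share one core and were tested in an assay on isolated protein for inhibition of aldehyde dehydrogenase 1A1 (Homo sapiens), read by spectrophotometry, tested at 10 uM; on this read-out higher numbers stand for more inhibition at the one concentration tested (going by the name of the read-out) and lower numbers for less inhibition. Compound 2 stands second highest of the three; its nearest neighbour is compound 3, whose number lies within the scatter of that of compound 2, while compound 1 sits well below it, beyond the scatter.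

Compound 4 `O=C(C1CC1)N1CCN(Cc2nc3ccccc3n2Cc2ccccc2)CC1` has not yet been measured. It differs from compound 2 in one place: hydrogen in place of fluoro on an aromatic carbon.

For the measured compounds named here, only one measured step touches this region: a number 19.9 percentage points higher from compound 1 to compound 2 (beyond the scatter). That step, however, introduced the whole 2-fluorophenyl at once, so it cannot separate the share of the fluoro from the share of the rest of the group. Going by the values given here, no measured pair isolates a fluoro-to-hydrogen exchange on that ring. The step expected in this assay from compound 2 to compound 4 is therefore small, with the fluoro's own contribution uncertain in direction, and is likely to fall within the scatter: a number 5.7 percentage points lower from compound 2 to compound 4 (within the scatter).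

Compound 4 is estimated to give 35%, with a range from 20% to 50%.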

Compound 4, a percentage reported as inhibition, at one concentration (the size of the read-out at that concentration, not a potency): 23.9%
Estimate against measurement, compound 4: 11.1 percentage points above; the range from low to high includes it.
By their numbers in this assay, from the lowest: compounds 1 and 4 (each within the scatter of the next); then compounds 2 and 3 (each within the scatter of the next).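

In this assay, the single fluoro proves to matter on its own: taking it off the ring gives a number 16.8 percentage points lower from compound 2 to compound 4 (beyond the scatter). Phenyl in place of methyl gives only a number 3.1 percentage points higher from compound 1 to compound 4 (within the scatter), so the earlier rise with 2-fluorophenyl does not come from the aromatic ring alone and depends on the fluoro being present. No measurement among these compounds explains this effect of the fluoro.

On these data alone, what chloro or methoxy on the same aromatic carbon would give remains open, so these compounds cannot tell whether the gain is particular to fluoro. As far as these compounds go, it also remains open whether the fluoro would give a similar step alongside the other carbonyl group seen in compound 3.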